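The source may report more compounds than this note shows. Statements on the series, on what has been measured and on what is new or still open speak of the compounds shown alone.

Measured in an ADME assay on tissue (ZR-75-1 cells, Homo sapiens) for pharmacokinetics; on this read-out lower numbers stand for a shorter-lived compound and higher numbers for a longer-lived compound:
- compound 1 `N[C@@H](CCC(=O)OC[C@H]1O[C@@H](n2cc(F)c(=O)[nH]c2=O)C[C@@H]1OC(=O)CC[C@H](N)C(=O)O)C(=O)O`: 0.238 h
- compound 2 `CC(C)[C@H](N)C(=O)OC[C@H]1O[C@@H](n2cc(F)c(=O)[nH]c2=O)C[C@@H]1OC(=O)[C@@H](N)C(C)C`: 0.112 h
- compound 3 `N[C@@H](CCC(=O)O[C@H]1C[C@H](n2cc(F)c(=O)[nH]c2=O)O[C@@H]1CO)C(=O)O`: 0.132 h

Compound 1 has the largest number of the three, though only compound 2 lies beyond the scatter from it. Compound 3 does not.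

Next in the series is compound 4 `N[C@@H](CCC(=O)OC[C@H]1O[C@@H](n2cc(F)c(=O)[nH]c2=O)C[C@@H]1O)C(=O)O`, not yet measured. Its difference from compound 1 is hydrogen in place of (3-amino-3-carboxypropyl)carbonyl on an oxygen on a saturated carbon.

Among the measured compounds shown here, one measured step bears on this: a 1.8-fold lower number from compound 1 to compound 3 (0.26 log units; within the scatter). It is the same exchange of the same group, made on a different oxygen. For the measured compounds named here, it is a single step and stays within the scatter, so it gives only a weak guide, and no measured step covers this oxygen itself. A modest fall of similar size is the working expectation, estimated as a 1.6-fold lower number from compound 1 to compound 4 (0.20 log units; within the scatter). Compound 4 is expected at 0.15 h, with an estimated range of 0.08 h to 0.27 h.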

Compound 4, half-life: 0.205 h
Beside the measured number, compound 4's estimate is 1.4-fold (0.14 log units) below it, within the range that was stated.
By their numbers in this assay, from the lowest: compounds 2, 3, 4 and 1 (each within the scatter of the next, the first and the last beyond it).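

In this assay, hydrogen in place of (3-amino-3-carboxypropyl)carbonyl at this oxygen gives a 1.2-fold lower number from compound 1 to compound 4 (0.06 log units; within the scatter) and so gives this position a measured step of its own, one that stays within the scatter. The same exchange on the other oxygen gives a 1.8-fold lower number from compound 1 to compound 3 (0.26 log units; within the scatter) and also stays within the scatter, so among the compounds shown, neither single exchange of this group takes the half-life beyond the scatter from compound 1. No evidence is available that bears on the cause of this result.

Still open, on these data alone, is how an amide link in place of the ester, or a longer chain on this oxygen, would read in this assay. Also open, as far as these compounds go, is whether hydrogen on both oxygens together would take the half-life beyond the scatter from compound 1.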